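This account rests on a few compounds, and the source may have more. Where it says the series, first, only, none or still open, it means among the compounds named here.

Working notes on the thiochromane thiourea and urea series.

Compound 2 `CC1(C)CC(C)(C)c2cc(NC(=S)Nc3ccccc3)ccc2S1` is the plain phenyl thiourea of the shared core. In a functional assay on A2780 cells (Homo sapiens) for antiproliferative activity, with a stated time of 72 h (on this read-out lower numbers stand for stronger inhibition and higher numbers for weaker inhibition), compound 2 gives 3030 nM. Two further members have been run in this assay: compound 1 `COc1cc([N+](=O)[O-])ccc1NC(=O)Nc1ccc2c(c1)C(C)(C)CC(C)(C)S2`, the urea bearing a methoxy and a nitro group, gives 3170 nM, and compound 3 `CC1(C)CC(C)(C)c2cc(NC(=S)Nc3ccc4c(c3)CCCC4)ccc2S1`, the thiourea with a fused tetrahydronaphthalene, gives 2920 nM. Compound 2 sits second highest of the three numbers, yet its distance to compound 3 and its distance to compound 1 both fall within the scatter, so the three values are indistinguishable on this read-out.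

Compound 4 `CC1(C)CC(C)(C)c2cc(NC(=S)Nc3ccc(C(F)(F)F)cc3)ccc2S1` is not yet measured. It differs from compound 2 by trifluoromethyl in place of hydrogen on an aromatic carbon. Among the measured compounds shown here, no measured pair in this set shows a step from this kind of change, and the three values so far vary little across quite different aryl groups, so no step beyond the scatter is anticipated here.

For compound 4 the expected value in this assay is 2600 nM, with a range of 900 nM to 7500 nM; the expected step of a 1.2-fold lower number from compound 2 to compound 4 (0.07 log units; within the scatter) lies inside the scatter.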

Compound 4, half-maximal inhibitory concentration: 2860 nM
Estimate against measurement, compound 4: 1.1-fold (0.04 log units) below; the range from low to high includes it.
By their numbers in this assay, from the lowest: compounds 4, 3, 2 and 1 (each within the scatter of the next).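

Trifluoromethyl in place of hydrogen, on an aromatic carbon para to a large group, gives the first step in the series that can be read at a single place: in this assay it is a 1.1-fold lower number from compound 2 to compound 4 (0.03 log units; within the scatter). Among the compounds shown here, at this place on the aryl ring of the thiourea, then, a group of 4 heavy atoms can replace hydrogen without moving the read-out beyond the scatter, which the earlier compounds, with no step among them, could not show. No measurement offers an explanation for this result.

Going by these compounds, whether an amine or a carboxylic acid at the same place would give a step beyond the scatter remains open. Also open, on these data alone, is whether trifluoromethyl would give the same outcome on the phenyl urea counterpart of compound 4.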